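Shortening the side chain of compound 1: an estimate

The source may report more compounds than this note shows. Statements on the series, on what has been measured and on what is new or still open speak of the compounds shown alone.

Measured compounds:
compound 1, `N=C(N)NCCC[C@H](NC(=O)CN(c1nc(Cl)nc2[nH]cnc12)C1CC1)C(=O)OCc1ccccc1`, 10.2%
compound 2, `NC(=O)CC[C@H](NC(=O)CN(c1ncnc2c1ncn2C1CCCCO1)C1CC1)C(=O)OCc1ccccc1`, 22.3%
compound 3, `O=C(O)CC[C@H](NC(=O)CN(c1nc(Cl)nc2[nH]cnc12)C1CC1)C(=O)O`, 30.1%

Of the compounds shown here, three have been measured in a functional assay on the whole organism (Tail, strain ICR) with Mus musculus as the target, in the tail flick test, with a stated time of 120 min, at a dose of 25 umol/kg by the oral route; on this read-out lower numbers stand for a weaker effect and higher numbers for a stronger effect at the one dose given. Compound 1 gives 10.2%, the lowest of the three numbers. Compound 2 gives 22.3%, and compound 3 gives 30.1%; both differences to compound 1 lie beyond the scatter, though neither pair differs in only one place, so no single step can be read from them.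

Compound 4, `C[C@H](NC(=O)CN(c1nc(Cl)nc2[nH]cnc12)C1CC1)C(=O)OCc1ccccc1`, has not been measured. It differs from compound 1 by a hydrogen atom in place of a group of 6 heavy atoms (3 carbon, 3 nitrogen; no ring), on a saturated chain carbon, two bonds along the chain from an amide-type nitrogen and a carbonyl carbon. Within the data shown here, no measured pair shows what this change alone does, so the expectation rests only on compound 1 and on the spread of the three numbers.

Compound 4 is expected to give 16%, with a range from 3% to 34%. The expected step is a number 5.8 percentage points higher from compound 1 to compound 4 (within the scatter), an upward step that is small and barely beyond the scatter, since compound 1 stands at 10.2% and every other measured compound stands higher.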

Compound 4, a percentage reported as activity, at one dose (the size of the read-out at that dose, not a potency): 36.1%
Compound 4: the middle estimate sits 20.1 percentage points below what was measured; the measured number lies above the stated range.
By their numbers in this assay, from the lowest: compound 1; then compounds 2, 3 and 4 (each within the scatter of the next, the first and the last beyond it).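

In this assay, among these compounds, the hydrogen atom in place of the group of 6 heavy atoms (3 carbon, 3 nitrogen; no ring) gives a number 25.9 percentage points higher from compound 1 to compound 4 (beyond the scatter), the first change in this set that can be read on its own. It shows that, on this saturated chain carbon, two bonds along the chain from an amide-type nitrogen and a carbonyl carbon, the group is not required for the effect at the one dose given, since the number rises when it leaves. Nothing available accounts for this rise.

As far as these compounds go, whether any replacement at this carbon would do the same remains open, for instance a shorter chain ending in a primary amine or in a hydroxyl group. Also open, from the compounds shown here alone, is whether the step would hold at other doses or times.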